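A few compounds are considered here, and "the series" means these few. Any claim that something is new, unique, unknown or untested is made for them only; others in the source may bear on it.

Measured compounds:
compound 1, `Cc1cccc(-n2cc(C(C)NC(=O)c3cc(C(F)(F)F)nn3C)cn2)c1`, 1600 nM
compound 2, `C[C@H](NC(=O)c1cc(C(F)(F)F)nn1C)c1nc(-c2ccccn2)no1`, > 30000 nM

In an assay on T-REx-293 cells for inhibition of potassium channel subfamily T member 1 (Homo sapiens), read by patch clamp (on this read-out higher numbers stand for weaker inhibition and lower numbers for stronger inhibition), compound 1 gives 1600 nM. For compound 2 this assay returns only a limit, > 30000 nM, and so compound 2 stands at the limit of > 30000 nM in this assay, at which 1 of the 2 values shown sits, the weaker end of the two values shown. No number is known for it, only that it lies beyond that limit.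

Compound 3 is `COCc1cc(-c2noc([C@H](C)NC(=O)c3cc(C(F)(F)F)nn3C)n2)ccn1`. It differs from compound 2 in one place: 2-(methoxymethyl)pyridin-4-yl in place of pyridin-2-yl on an aromatic carbon. Because compound 2 stands at the limit of > 30000 nM in this assay, at which 1 of the 2 values shown sits, any step from it can only be read against a limit, not a number. A step toward stronger inhibition is expected, of a size an at least 2.5-fold lower number from compound 2 to compound 3 (0.39 log units; beyond the scatter), though it may stay within the scatter. Compound 3 is therefore estimated at 12000 nM, with a range from 3000 nM to 40000 nM.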

Compound 3, half-maximal inhibitory concentration: 322 nM
For compound 3 the middle estimate is 37-fold (1.57 log units) above the measured one; the measured number lies below the stated range.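

On the aromatic carbon between two ring nitrogen atoms, replacing pyridin-2-yl with 2-(methoxymethyl)pyridin-4-yl gives, in this assay, an at least 93-fold lower number from compound 2 to compound 3 (1.96 log units; beyond the scatter). This shows that the position can respond strongly: with the rest of the structure unchanged, the group on this one carbon is the only difference, and compound 3 has a measured value of 322 nM. Compound 2 gives only a limit, so the full size of the step remains unknown: the limit of > 30000 nM in this assay, at which 1 of the 3 values shown sits.

The change moves the ring attachment and adds the methoxymethyl chain in a single step, so the compounds shown do not separate the contributions of the two. They also leave open how plain pyridin-4-yl, or a pyridin-4-yl ring carrying a hydroxymethyl group or an amine in place of the methoxymethyl chain, would read out here.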